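Methylating the Aniline Nitrogen of Compound 1

The source may report more compounds than this note shows. Statements on the series, on what has been measured and on what is new or still open speak of the compounds shown alone.

Compound 1 `COc1ccc(Nc2nc(NC3CCCC3)c3ccccc3n2)cc1` gives 12400 nM
Compound 2 `COc1ccc(Nc2nc(NCCCO)c3ccccc3n2)cc1` gives 18300 nM
Compound 3 `CNc1nc(Nc2ccc(OC)cc2)nc2ccccc12` gives 14300 nM

In a functional assay on DU-145 cells (Homo sapiens) for antiproliferative activity, read by sulforhodamine B assay, with a stated time of 48 h (on this read-out higher numbers stand for weaker inhibition of growth and lower numbers for stronger inhibition of growth), compound 1 gives 12400 nM and cannot be told apart from the other two compounds. The steps of a 1.5-fold higher number from compound 1 to compound 2 (0.17 log units; within the scatter) and a 1.2-fold higher number from compound 1 to compound 3 (0.06 log units; within the scatter) both lie within the scatter, as does a 1.3-fold lower number from compound 2 to compound 3 (0.11 log units; within the scatter) too. Compound 4 `COc1ccc(N(C)c2nc(NC3CCCC3)c3ccccc3n2)cc1` keeps the core of compound 1 and differs in one place, as methyl in place of hydrogen on a nitrogen on an aromatic ring shows: methyl in place of hydrogen on a nitrogen on an aromatic ring. Within the data shown here, no measured step covers this change, for all of them alter the group standing in place of cyclopentyl and leave this hydrogen untouched. No step beyond the scatter is therefore expected in this assay in either direction, though this expectation is loosely supported. The expected step is a 1.1-fold lower number from compound 1 to compound 4 (0.05 log units; within the scatter) as a rough estimate. For compound 4 the estimated value is 11000 nM with an expected range of 3000 nM to 30000 nM in this estimate.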

Compound 4, concentration for 50% growth inhibition in the DU-145 assay: 10200 nM
Compound 4: the middle estimate sits 1.1-fold (0.03 log units) above what was measured; measured number inside the range.
By their numbers in the DU-145 assay, from the lowest: compounds 4, 1, 3 and 2 (each within the scatter of the next).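

Methyl in place of hydrogen on a nitrogen on an aromatic ring is the first change shown at this position, and in the DU-145 assay it stays within the scatter, with a 1.2-fold lower number from compound 1 to compound 4 (0.08 log units; within the scatter). The same change does register in a physicochemical assay for solubility, read by HPLC, in phosphate buffer, at pH 7.4 (a higher number here means a more soluble compound, a lower number a less soluble compound), where compound 1 gives 10.4 ug/mL and compound 4 gives 1.11 ug/mL and solubility drops: the measured solubility of compound 1, 10.4 ug/mL, and of compound 4, 1.11 ug/mL, a 9.4-fold lower number (0.97 log units; beyond the scatter). At this position, then, the two read-outs part ways for this one pair.

The compounds shown leave open whether an ethyl group or a chain carrying an amine on this nitrogen would behave the same way in the DU-145 assay and the physicochemical assay. They also leave open whether the methyl step repeats when 3-hydroxypropyl stands in place of cyclopentyl.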